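Amide substituent change at the weak end of the series

The compounds below may be only part of what the source reports. "The series", "measured", "known", "first", "only" and "open" are said of these compounds alone.

For the measured compounds named here, compound 1 `C=CC1=C(C(=O)Nc2ccc(C)cc2)C(c2ccc(F)cc2)OC1` is the only member of this pair with a numeric result in a functional assay on QGY7701 cells (Homo sapiens) for cytotoxicity, read by MTT assay, with a stated time of 24 h; a lower number here means a stronger inhibitor, a higher number a weaker inhibitor; compound 1 gives 59200 nM. Compound 2 `C=CC1=C(C(=O)Nc2ccc(C)cc2)C(c2ccc(OC)cc2)OC1` reaches only a limit of the assay, returning > 100000 nM in this assay. Going by the values given here, the one measured step, an at least 1.6-fold higher number from compound 1 to compound 2 (0.22 log units; that floor lies within the scatter), rests on that limit of > 100000 nM in this assay, at which 1 of the 2 values shown sits, and therefore sets a floor rather than a size.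

Compound 3 `C=CC1=C(C(=O)NCCCCC)C(c2ccc(F)cc2)OC1` differs from compound 1 by pentyl in place of 4-methylphenyl on an amide-type nitrogen. Among the compounds with values here, no measured step touches the amide-type nitrogen; the single step known concerns a substituent on an aromatic carbon elsewhere, so it has no direct bearing on this change and the direction is left open by the data. Within the data shown here, with compound 1 already weak and compound 2 at the limit, the series so far gives no sign of a large gain in this assay. A step of a 1.4-fold higher number from compound 1 to compound 3 (0.13 log units; within the scatter) is expected, within or near the scatter, with a real chance that only a limit is returned. Compound 3 is therefore estimated at 80000 nM in this assay, in a range from 30000 nM to 200000 nM.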

Compound 3, half-maximal inhibitory concentration: > 100000 nM
Compound 3: only a limit was reported (the forecaster's own chance of this, stated with the estimate: 35%); at least 1.2-fold (0.09 log units) between middle value and limit.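

Pentyl in place of 4-methylphenyl on the amide-type nitrogen is the first change at this position, and in this assay compound 3 gives > 100000 nM, which is a limit of the assay and not a number. The change reads as an at least 1.6-fold higher number from compound 1 to compound 3 (0.22 log units; that floor lies within the scatter), so it sets a floor and not a size, and swapping the aromatic ring for an open chain brings no lower number at this position. With the fluoro group kept, the amide-type nitrogen now joins the aromatic carbon as a second place where a single change from compound 1 ends at the assay limit: the limit of > 100000 nM in this assay, at which 2 of the 3 values shown sit.

As far as these compounds go, how far compound 2 and compound 3 each lie past that limit stays unknown, so neither the true size of either step nor any order between them can be read. Also open, from the compounds shown here alone, is whether a longer chain, or a chain carrying an amine or a carboxylic acid, on the amide-type nitrogen would return a number in this assay and not a limit.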